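Shortening the Basic Amine Chain on the Amide Nitrogen

This account rests on a few compounds, and the source may have more. Where it says the series, first, only, none or still open, it means among the compounds named here.

Going by the values given here, compound 1 `O=C(CCC(=O)OCCCCCCSc1ccc([N+](=O)[O-])c2nonc12)Nc1ccccc1F` gives 350 nM in an assay on isolated protein for inhibition of glutathione S-transferase Mu 2 (Homo sapiens), with a stated time of 10 min (a higher number here means a weaker inhibitor, a lower number a stronger inhibitor), the highest of the two numbers measured so far. Compound 2 `CN(C)CCCNC(=O)CCC(=O)OCCCCCCSc1ccc([N+](=O)[O-])c2nonc12` gives 90 nM in this assay, a step of a 3.9-fold lower number from compound 1 to compound 2 (0.59 log units; beyond the scatter). Compound 3 `CN(C)CCNC(=O)CCC(=O)OCCCCCCSc1ccc([N+](=O)[O-])c2nonc12` has not yet been measured; it differs from compound 1 by 2-(dimethylamino)ethyl in place of 2-fluorophenyl on an amide-type nitrogen. Among the compounds with values here, the only step that bears on this change is the one to compound 2, which was modest and beyond the scatter, so a lower number of similar size is expected here. For compound 3 the expected step is a 3.2-fold lower number from compound 1 to compound 3 (0.50 log units; beyond the scatter). Compound 3 is therefore estimated at 110 nM, between 40 nM and 300 nM.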

Compound 3, half-maximal inhibitory concentration: 160 nM
Compound 3: middle estimate off by 1.5-fold (0.16 log units), on the low side; the measured number falls inside the stated range.
By their numbers in this assay, from the lowest: compounds 2 and 3 (each within the scatter of the next); then compound 1.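

Compound 3 shows that the advantage over 2-fluorophenyl on the amide-type nitrogen does not depend on one chain length: 2-(dimethylamino)ethyl also gives a step beyond the scatter in this assay (a 2.2-fold lower number from compound 1 to compound 3 (0.34 log units; beyond the scatter)). Between the two chains the difference stays within the scatter (a 1.8-fold higher number from compound 2 to compound 3 (0.25 log units; within the scatter)), so the compounds do not separate them.

As far as these compounds go, whether a longer chain such as 4-(dimethylamino)butyl, or a piperidine ring in place of the dimethylamino group, would keep this level remains open. Why the amine-bearing chains differ from 2-fluorophenyl also remains open, as no measurement here addresses it.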